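Trimming the Tail of a Ketoamide Calpain Inhibitor

The source may hold more compounds than are shown below. What is called first, only, known or untested is meant among the compounds shown, and "the series" means these compounds.

Measured compounds:
compound 1, `CCOC(=O)C(=O)C(CC)NC(=O)C(CC(C)C)NC(=O)C(CC)Oc1ccccc1`: 1400 nM
compound 2, `CCC(NC(=O)C(CC(C)C)NC(=O)OCc1ccccc1)C(=O)C(=O)NCC(C)C`: 140 nM

In an assay on isolated protein (Oryctolagus cuniculus) for inhibition of Calpain-2 catalytic subunit (Homo sapiens), at pH 8.0 (a higher number here means a weaker inhibitor, a lower number a stronger inhibitor), compound 1 gives 1400 nM, and compound 2 gives 140 nM. Compound 2 thus has the lower of the two numbers, and its gap to compound 1 lies beyond the usual scatter of repeated measurements.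

Compound 3, `CCC(NC(=O)C(CC(C)C)NC(=O)OCc1ccccc1)C(=O)C(=O)O`, has not yet been measured in this assay. It keeps the shared core of compound 2 and differs in one place: hydroxy in place of isobutylamino on a carbonyl carbon. In other words, the chain that ends compound 2 is cut back, leaving a carboxylic acid in its place.

Among the compounds with values here, with no measured pair showing this exact change, the expectation rests on the numbers for compound 2 alone. The step from compound 2 to compound 3 is expected to be a 7.1-fold higher number from compound 2 to compound 3 (0.85 log units; beyond the scatter), that is, a move to a higher number. Compound 3 is therefore estimated at 1000 nM, with a likely range from 200 nM to 5000 nM.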

Compound 3, inhibition constant: 22 nM
Beside the measured number, compound 3's estimate is 45-fold (1.66 log units) above it; the measured number lies below the stated range.
By their numbers in this assay, from the lowest: compound 3; then compound 2; then compound 1.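

Replacing isobutylamino with hydroxy on this carbonyl carbon gives a 6.4-fold lower number from compound 2 to compound 3 (0.80 log units; beyond the scatter) in this assay, and that step lies beyond the usual scatter. The isobutylamino group, with its 5 heavy atoms, is therefore not required for inhibition in this series, since the shorter carboxylic acid end gives the lower number of the matched pair. The earlier comparison could not show this: compound 1 and compound 2 differ in more than one place, so their gap could not be assigned to this position, whereas this single change isolates the end of the chain.

This one matched pair leaves open how the number changes along a series of replacements at the same carbonyl carbon, such as a plain amide, a methyl ester or a shorter chain like ethylamino, and whether the same swap would have a similar effect on a different core. Nothing in the available data explains why the loss of the isobutylamino group goes with a lower number.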